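A Second Chloro Added to Two Related Cores

A few compounds are considered here, and "the series" means these few. Any claim that something is new, unique, unknown or untested is made for them only; others in the source may bear on it.

Compound 1 `O=C(/C(=C/c1ccc(Cl)cc1)CCl)c1ccccc1` and compound 2 `O=C(/C(=C/c1ccc(Cl)cc1Cl)CCl)c1ccccc1` share one core, while compound 3 `CC(=O)OC/C(=C\c1ccc(Cl)cc1)C(=O)c1ccc(Cl)cc1` and compound 4 `CC(=O)OC/C(=C\c1ccc(Cl)cc1Cl)C(=O)c1ccc(Cl)cc1` share another; the difference between the two cores is not broken down here.

In a functional assay on HeLa cells (Homo sapiens) for inhibition, read by sulforhodamine B assay, with a stated time of 48 h (on this read-out higher numbers stand for weaker inhibition of growth and lower numbers for stronger inhibition of growth), compound 1 gives 22000 nM and compound 2 gives 15000 nM. The change that separates them is chloro in place of hydrogen on an aromatic carbon. It produced a 1.5-fold lower number from compound 1 to compound 2 (0.17 log units; within the scatter), so the two values are not distinguishable on this read-out.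

In this assay compound 3 gives 19000 nM, a value that sits close to both compound 1 and compound 2, with all three gaps within the scatter. Compound 4 has not yet been measured. It differs from compound 3 by chloro in place of hydrogen on an aromatic carbon. The place at which the chloro enters is described in the same words for both pairs, so this is the same change that was made from compound 1 to compound 2, now carried out on the core of compound 3.

Resting on the step of a 1.5-fold lower number from compound 1 to compound 2 (0.17 log units; within the scatter) that the same change gave, the expected step for compound 4 is a 1.5-fold lower number from compound 3 to compound 4 (0.16 log units; within the scatter). In this assay compound 4 is therefore estimated at 13000 nM, with the likely range running from 6000 nM to 28000 nM, and nothing among the shown compounds points to a larger shift.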

Compound 4, concentration for 50% growth inhibition: 4600 nM
Compound 4: the middle estimate sits 2.8-fold (0.45 log units) above what was measured; measured number below the stated range.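

On the second core in this assay, the change from 4-chlorophenyl to 2,4-dichlorophenyl gave a 4.1-fold lower number from compound 3 to compound 4 (0.62 log units; beyond the scatter), a step that stands clear of the usual scatter, whereas the step on the first core does not. The same change therefore did not carry over from one core to the other with the same size: the same change on two cores in this assay, a 1.5-fold lower number (0.17 log units; within the scatter) from compound 1 to compound 2 and a 4.1-fold lower number (0.62 log units; beyond the scatter) from compound 3 to compound 4, 2.8-fold (0.45 log units) apart, beyond the scatter of two such steps. This shows that, in these two pairs, a step read on one core was a poor guide to its size on the other, but two pairs do not show which feature of the cores goes with the difference, nor how the change would behave on any further core.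

The compounds shown leave open which part of the difference between the two cores goes with the larger step, as well as whether the step on the second core would recur in other compounds built on that core. They also leave open whether a fluoro, a methyl or a methoxy group entering at the same place would give a step like that of the chloro group on either core.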